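Series notes: cytotoxicity, compound 3 to compound 4

The compounds below may be only part of what the source reports. "The series", "measured", "known", "first", "only" and "open" are said of these compounds alone.

Measured so far in an ADME assay on HEK293 cells (Homo sapiens) for cytotoxicity, read by CellTiter-Glo and resazurin assay, with a stated time of 72 h; a lower number here means that less compound is needed, a higher number that more compound is needed for the effect:
Compound 1, `CC(C)N(Cc1cccc(OCCCCCC(=O)O)c1)C(=O)c1ccc(-c2ccc3cc[nH]c3c2)cc1`, reaches only the assay limit of > 26000 nM.
Compound 2, `COc1cc(OC)cc(-c2ccc(C(=O)N(Cc3cccc(OCCCCCC(=O)O)c3)C(C)C)cc2)c1`, reaches only the assay limit of > 26000 nM.
Compound 3, `CCOC(=O)CCCCCOc1cccc(CN(C(=O)c2ccc(-c3cccnc3)cc2)C(C)C)c1`, reaches only the assay limit of > 26000 nM.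

Within the data shown here, the one step within the measured set, a step that the two limits leave unreadable from compound 1 to compound 2, cannot be read: both its ends are limits. Compound 3 thus stands at the limit of this assay, alongside the two other values shown (the limit of > 26000 nM in this assay, at which 3 of the 3 values shown sit). Compound 4, `CCOC(=O)CCCCCOc1cccc(CN(C(=O)c2ccc(-c3cccc(F)c3)cc2)C(C)C)c1`, differs from compound 3 by 3-fluorophenyl in place of pyridin-3-yl on an aromatic carbon. Among the measured compounds shown here, no measured step bears on this change, since the only step available is unreadable and every value sits at the limit. The expected step of a number no higher from compound 3 to compound 4 (the limit leaves the size open) is therefore none beyond the scatter. Compound 4 is estimated at 26000 nM, with a range of 13000 nM to 52000 nM, and most probably returns again as a limit in this assay.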

Compound 4, half-maximal effective concentration: > 26000 nM
Compound 4: a limit, no number; the forecaster's own chance of this, stated with the estimate: 85%; the middle value lies on the limit itself.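

In this assay compound 3 and compound 4 both stand as limits, and the step between them cannot be read. The compounds shown leave open at what concentration any of them reaches the half-maximal effect, and whether 3-fluorophenyl and pyridin-3-yl differ at all.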